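Liver microsome half-life: from lactam to oxadiazolone

The source may hold more compounds than are shown below. What is called first, only, known or untested is meant among the compounds shown, and "the series" means these compounds.

Measured so far:
compound 1, `CC(C)C(c1ccc(-c2ccc3cccc(F)c3c2)[nH]c1=O)N1CCCCS1(=O)=O`: 0.373 h
compound 2, `CC(C)C(c1ccc(-c2ccc3cccc(F)c3c2)[nH]c1=O)N1CCCCC1=O`: 0.183 h

For the measured compounds named here, in an ADME assay on microsomes from liver (Homo sapiens) for metabolic stability (on this read-out higher numbers stand for a longer-lived compound and lower numbers for a shorter-lived compound), compound 2 gives 0.183 h and stands lowest of the two numbers; compound 1 is nearest, reached by a 2.0-fold lower number from compound 1 to compound 2 (0.31 log units; beyond the scatter), the only measured step. Compound 3, `CC(C)C(Cc1noc(=O)[nH]1)c1ccc(-c2ccc3cccc(F)c3c2)[nH]c1=O`, is not yet measured. It differs from compound 2 by a group of 7 heavy atoms (3 carbon, 2 nitrogen, 2 oxygen; one five-membered aromatic ring with 3 hetero atoms) in place of a group of 7 heavy atoms (5 carbon, 1 nitrogen, 1 oxygen; one six-membered non-aromatic ring with 1 hetero atom), on a saturated chain carbon bound to an aromatic carbon and a saturated chain carbon. Going by the values given here, no measured step concerns this change; the one measured step touches a different pair of groups at the same place. The expectation for compound 3 is therefore a number near compound 2, with no step beyond the scatter, a 1.1-fold higher number from compound 2 to compound 3 (0.04 log units; within the scatter). Compound 3 is estimated at 0.2 h, between 0.08 h and 0.5 h.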

Compound 3, half-life: > 3 h
Compound 3 ended at the assay's limit; the forecaster's own chance of this, stated with the estimate: 5%; at least 15-fold (1.17 log units) between middle value and limit.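

In this assay, for the compounds shown here, the place on the saturated chain carbon proves far more sensitive than the first pair of compounds showed: putting the five-membered aromatic ring group in place of 2-oxopiperidin-1-yl gives an at least 16-fold higher number from compound 2 to compound 3 (1.21 log units; beyond the scatter). The same ring group in place of the six-membered ring of compound 1 gives an at least 8.0-fold higher number from compound 1 to compound 3 (0.90 log units; beyond the scatter). The value of compound 3 is a limit and not a number: the limit of > 3 h in this assay, at which 1 of the 3 values shown sits.

From the compounds shown here alone, how far the half-life of compound 3 lies past that limit stays open. So does whether a carboxylic acid or an amine at this place would give a comparable half-life.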